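Trifluoromethylphenyl arm replacing fluorophenyl on compound 1

The compounds below may be only part of what the source reports. "The series", "measured", "known", "first", "only" and "open" are said of these compounds alone.

Compound 1 `Oc1ccc(-c2cc(-c3ccc(F)cc3)cc(-c3ccccc3O)n2)cc1` in a functional assay on T47D cells (Homo sapiens) for inhibition (a higher number here means a weaker inhibitor, a lower number a stronger inhibitor), gives only a limit, > 50000 nM. That limit for compound 1 is noted in the limit of > 50000 nM in this assay, at which 1 of the 2 values shown sits. Compound 2 `Oc1ccc(-c2cc(-c3ccc(F)cc3)cc(-c3ccc(O)cc3)n2)cc1` in this assay gives 5260 nM. Within the data shown here, the single measured step, an at least 9.5-fold lower number from compound 1 to compound 2 (0.97 log units; beyond the scatter), alters the hydroxyphenyl arm and leaves the fluorophenyl arm untouched, so it does not bear directly on the change toward compound 3 `Oc1ccc(-c2cc(-c3ccccc3C(F)(F)F)cc(-c3ccccc3O)n2)cc1`. That change is 2-(trifluoromethyl)phenyl in place of 4-fluorophenyl on an aromatic carbon, with both hydroxyphenyl groups of compound 1 kept. Among the measured compounds shown here, no measured pair shows what this swap does in this assay. For the measured compounds named here, since compound 1 stands at a limit and no step of bearing exists, compound 3 is expected to stay near that limit, with a number no higher from compound 1 to compound 3 (the limit leaves the size open) taken as no step beyond the scatter. Compound 3 is therefore estimated at 50000 nM in this assay, within 15000 nM to 200000 nM, and most likely reported again only as a limit.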

Compound 3, half-maximal inhibitory concentration: 7180 nM
Compound 3: the middle estimate sits 7.0-fold (0.84 log units) above what was measured, and the stated range ends above it.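

The arm opposite the ring nitrogen is not a silent position in this assay: 2-(trifluoromethyl)phenyl in place of 4-fluorophenyl moves the series off the limit (an at least 6.9-fold lower number from compound 1 to compound 3 (0.84 log units; beyond the scatter)). Both hydroxyphenyl groups stay as in compound 1, so the 2-hydroxyphenyl group of compound 1 does not by itself hold activity beyond the assay limit, and a change on a second arm of the shared core also gives a measurable value (an at least 9.5-fold lower number from compound 1 to compound 2 (0.97 log units; beyond the scatter)). As far as these compounds go, the true size of the new step remains open-ended, since it is read from a limit: the limit of > 50000 nM in this assay, at which 1 of the 3 values shown sits.

Still open, from the compounds shown here alone, is whether the step follows from losing the 4-fluorophenyl group or from gaining the 2-(trifluoromethyl)phenyl group, which a plain phenyl or a methoxyphenyl arm here would help separate. Also open, going by these compounds, is whether the same swap adds to the step seen on the core of compound 2.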